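The compounds below may be only part of what the source reports. "The series", "measured", "known", "first", "only" and "open" are said of these compounds alone.

Compound 1 `Cc1nn(Cc2ccc(C(N)=O)cc2)c(C)c1NC(=O)c1ccc(COc2ccccc2)cc1` — in a functional assay on MIA PaCa-2 cells (Homo sapiens) for antiproliferative activity, read by MTT assay, with a stated time of 72 h (on this read-out lower numbers stand for an effect already at smaller amounts and higher numbers for an effect only at larger amounts of compound), compound 1 gives only a limit, > 100000 nM.
Compound 2 `CNC(=O)c1cccc(Cn2nc(C)c(NC(=O)c3ccc(COc4cccc(C)c4)cc3)c2C)c1` — compound 2 gives 6200 nM.
Compound 3 `CNC(=O)c1cccc(Cn2nc(C)c(NC(=O)c3ccc(COc4ccc(C)cc4)cc3)c2C)c1` — compound 3 gives 2600 nM.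

Compound 3 stands lowest of the two numbers; the nearest, compound 2, sits above it by a 2.4-fold lower number from compound 2 to compound 3 (0.38 log units; beyond the scatter). Compound 4 `CNC(=O)c1cccc(Cn2nc(C)c(NC(=O)c3ccc(COc4cccc(Cl)c4)cc3)c2C)c1` differs from compound 3 by 3-chlorophenyl in place of 4-methylphenyl on an oxygen on a saturated carbon. Going by the values given here, only one measured step bears on this: the move of methyl between the same two ring positions, a 2.4-fold lower number from compound 2 to compound 3 (0.38 log units; beyond the scatter), modest but beyond the scatter. Among the compounds with values here, no measured pair speaks to chlorine itself, so the new substituent is read as a return to the position of compound 2. Compound 4 is therefore expected to give 5500 nM, within 2000 nM to 16000 nM, a step of a 2.1-fold higher number from compound 3 to compound 4 (0.33 log units; beyond the scatter) expected beyond the scatter.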

Compound 4, half-maximal effective concentration: 5900 nM
Beside the measured number, compound 4's estimate is 1.1-fold (0.03 log units) below it; measured number inside the range.
By their numbers in this assay, from the lowest: compound 3; then compounds 4 and 2 (each within the scatter of the next). At a limit, above all of these: compound 1.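

In this assay, chloro and methyl on this aromatic carbon cannot be told apart, with a 1.1-fold lower number from compound 2 to compound 4 (0.02 log units; within the scatter). By contrast, 3-chlorophenyl in place of 4-methylphenyl on the oxygen gives a 2.3-fold higher number from compound 3 to compound 4 (0.36 log units; beyond the scatter), so among the three measured numbers only the 4-methylphenyl group stands apart, with the lowest. Nothing measured here accounts for either step.

The compounds shown leave open whether a methoxy group or an amine in place of chloro would keep this level, and whether any such group would reach below the number of the 4-methylphenyl group.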